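Trimming methoxy groups: from compound 1 to compound 4

The compounds below may be only part of what the source reports. "The series", "measured", "known", "first", "only" and "open" are said of these compounds alone.

In a functional assay on PC-3 cells (Homo sapiens) for antiproliferative activity, read by MTT assay, with a stated time of 48 h (on this read-out lower numbers stand for stronger inhibition and higher numbers for weaker inhibition), compound 1 (`COc1ccc(CN(C(=O)COc2cc(OC)c(OC)c(OC)c2)c2cc(OC)c(OC)c(OC)c2)cc1`) gives > 80000 nM as its reading, which is a limit of the assay and not a number. Compound 4 (`COc1ccc(CN(C(=O)COc2ccc(OC)cc2)c2cc(OC)c(OC)c(OC)c2)cc1`) carries 4-methoxyphenyl in place of 3,4,5-trimethoxyphenyl on an oxygen on a saturated carbon. Two relatives give real numbers in this assay for comparison. Compound 2 (`COc1ccc(CN(C(=O)CSc2nnnn2C)c2cc(OC)c(OC)c(OC)c2)cc1`) gives 10500 nM and compound 3 (`COc1ccc(CN(C(=O)CSc2nncs2)c2cc(OC)c(OC)c(OC)c2)cc1`) gives 5530 nM on this scale. Among the measured compounds shown here, the one measured step is a 1.9-fold lower number from compound 2 to compound 3 (0.28 log units; within the scatter) and it swaps a different group on a sulfur, so it offers no direct size for this change. Still, with compound 3 at 5530 nM as a guide, a step to a lower number is expected for a molecule without the 3,4,5-trimethoxyphenyl group. The expected step is an at least 4.0-fold lower number from compound 1 to compound 4 (0.60 log units; beyond the scatter) and it starts from a limit, so it is only a rough estimate. Compound 4 is estimated at 20000 nM with an expected range from 6000 nM to 80000 nM in this assay when measured.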

Compound 4, half-maximal inhibitory concentration: 66400 nM
Beside the measured number, compound 4's estimate is 3.3-fold (0.52 log units) below it; low and high end bracket the measured number.
By their numbers in this assay, from the lowest: compounds 3 and 2 (each within the scatter of the next); then compound 4. At a limit, above all of these: compound 1.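

From the compounds shown here alone, compound 1 stands at a limit of the assay, not at a number: the limit of > 80000 nM in this assay, at which 1 of the 4 values shown sits. In this assay, trimming to 4-methoxyphenyl brings the reading onto the measurable scale, with an at least 1.2-fold lower number from compound 1 to compound 4 (0.08 log units; that floor lies within the scatter), so the true size of this change stays unknown. The new value also shows that the group on the saturated chain carbon bound to a carbonyl carbon matters here: 4-methoxyphenoxy gives a 12-fold higher number from compound 3 to compound 4 (1.08 log units; beyond the scatter), and against the tetrazole-bearing group it gives a 6.3-fold higher number from compound 2 to compound 4 (0.80 log units; beyond the scatter).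

Both of those steps change the ring and the linking atom at once, so the compounds shown cannot say which of the two accounts for the gap. Going by these compounds, a 4-methoxyphenylsulfanyl group at this carbon would separate them, and how an amine on the phenyl ring would read remains open.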